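A few compounds are considered here, and "the series" means these few. Any claim that something is new, unique, unknown or untested is made for them only; others in the source may bear on it.

Compound 1 `Cc1cc(Cl)cc(C(=O)Nc2nn[nH]n2)n1` stands highest of the three numbers measured in a functional assay on the whole organism for inhibition, with Rattus norvegicus as the target, with a stated time of 5 min, at a dose of 3 mg/kg by the oral route (a higher number here means more inhibition at the dose given (going by the name of the read-out), a lower number less inhibition), where compound 1 gives 85%. Compound 3 `O=C(Nc1nn[nH]n1)c1cccc(/C=C/c2ccccc2)n1` comes nearest, giving 75%, a gap within the scatter. Going by the values given here, compound 2 `O=C(Nc1nn[nH]n1)c1cc(Cl)ccn1` lies furthest, giving 71%, and the step of a number 14 percentage points lower from compound 1 to compound 2 (beyond the scatter) is the only single change measured here. Compound 4 `Cc1cc(C)nc(C(=O)Nc2nn[nH]n2)c1` differs from compound 1 by methyl in place of chloro on an aromatic carbon. Among the compounds with values here, no measured step exchanges a chloro for a methyl, so the one measured step bears only loosely on it; its size is modest. Compound 4 is therefore expected to stay close to compound 1, with a step of a number 5 percentage points lower from compound 1 to compound 4 (within the scatter) not beyond the scatter. The estimate for compound 4 is 80%, between 65% and 92%.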

Compound 4, a percentage reported as inhibition, in the whole organism at one dose (the size of the read-out at that dose, not a potency): 37%
Estimate against measurement, compound 4: 43 percentage points above, and the stated range ends above it.
By their numbers in this assay, from the lowest: compound 4; then compounds 2, 3 and 1 (each within the scatter of the next, the first and the last beyond it).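

Going by these compounds alone, at the carbon opposite the ring nitrogen, replacing chloro with methyl is far from neutral in this assay, giving a number 48 percentage points lower from compound 1 to compound 4 (beyond the scatter), whereas the only earlier step, at a different place on the ring, was a number 14 percentage points lower from compound 1 to compound 2 (beyond the scatter). The change swaps one heavy atom for one, with no hydrogen-bond donor or acceptor counted on either side, so these counts do not separate the two groups. No measured evidence accounts for the drop. From the compounds shown here alone, whether a bromo, a methoxy or an amine at this place would behave like chloro or like methyl remains open.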